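Benzoyl on an aromatic nitrogen of compound 1

The compounds below may be only part of what the source reports. "The series", "measured", "known", "first", "only" and "open" are said of these compounds alone.

Measured so far in a functional assay on U-373MG ATCC cells (Homo sapiens) for inhibition, read by MTT assay, with a stated time of 72 h; on this read-out lower numbers stand for stronger inhibition of growth and higher numbers for weaker inhibition of growth:
Compound 1 `CC(C)[Si]1(C(C)C)OC[C@H]2O[C@@H](n3ccc(=O)[nH]c3=O)[C@H](O)[C@@H]2O[Si](C(C)C)(C(C)C)O1`: 81000 nM
Compound 2 `Cc1cn([C@@H]2O[C@@H]3CO[Si](C(C)C)(C(C)C)O[Si](C(C)C)(C(C)C)O[C@H]3[C@H]2O)c(=O)[nH]c1=O`: 87000 nM

The two measured values sit level: a 1.1-fold higher number from compound 1 to compound 2 (0.03 log units; within the scatter). For the measured compounds named here, this leaves compound 1 with no separation from its only measured neighbour. The next compound to be measured is compound 3 `CC(C)[Si]1(C(C)C)OC[C@H]2O[C@@H](n3ccc(=O)n(C(=O)c4ccccc4)c3=O)[C@H](O)[C@@H]2O[Si](C(C)C)(C(C)C)O1`, which differs from compound 1 by a single change: benzoyl in place of hydrogen on an aromatic nitrogen. Going by the values given here, only one measured step is available, and it bears on this change only loosely. That step, a 1.1-fold higher number from compound 1 to compound 2 (0.03 log units; within the scatter), puts methyl in place of hydrogen on an aromatic carbon, not benzoyl on an aromatic nitrogen. Among the compounds with values here, the data therefore hold no direct precedent for this change and indicate no direction. In this assay, no step beyond the scatter is expected, though the uncertainty is wide. The expected step is a 1.4-fold lower number from compound 1 to compound 3 (0.13 log units; within the scatter). The estimated value for compound 3 is 60000 nM, with an expected range from 18000 nM to 160000 nM.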

Compound 3, concentration for 50% growth inhibition: 29000 nM
The estimate for compound 3 lay 2.1-fold (0.32 log units) above the measured number, and the stated range covers the measured number.
By their numbers in this assay, from the lowest: compound 3; then compounds 1 and 2 (each within the scatter of the next).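

In this assay, the aromatic nitrogen of compound 1 proves to be a position where a change can move the number beyond the scatter: benzoyl in place of hydrogen gives a 2.8-fold lower number from compound 1 to compound 3 (0.45 log units; beyond the scatter) in a modest step. For the compounds shown here, the only earlier step, on an aromatic carbon, was a 1.1-fold higher number from compound 1 to compound 2 (0.03 log units; within the scatter) and stayed within the scatter, so it gave no sign of this. The hydrogen on this nitrogen is therefore not needed for growth inhibition in this series, but no measurement shown explains why the number falls.

From the compounds shown here alone, it remains open whether the aromatic ring or the carbonyl of benzoyl matters more, and whether acetyl or benzyl on the same nitrogen would give a similar step. Going by these compounds, it is also open whether benzoyl would do the same on compound 2.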